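Swapping fluoro for trifluoromethyl on the phenoxy ring

A few compounds are considered here, and "the series" means these few. Any claim that something is new, unique, unknown or untested is made for them only; others in the source may bear on it.

Compound 3 `CC(Oc1ccc(Oc2ccc(F)cc2)cc1)C(=O)Cn1nnc(-c2ccc(Cl)cc2)n1` was measured in a physicochemical assay for lipophilicity, read by HPLC, tested at 5 mM (on this read-out higher numbers stand for higher lipophilicity and lower numbers for lower lipophilicity), and gave 6.2. Compound 2 `CC(Oc1ccc(Oc2ccc(C(F)(F)F)cc2)cc1)C(=O)Cn1nnc(-c2ccccc2)n1` gave 6.2, so compound 3 stands level with compound 2 at the digits shown, the two together being the highest of the three numbers. Compound 1 `CC(Oc1ccc(Oc2ccc(F)cc2)cc1)C(=O)Cn1nnc(-c2ccccc2)n1` gave 5.3, and the climb a number 0.90 log units higher from compound 1 to compound 3 (beyond the scatter) lies beyond the scatter, so compound 3 sits clearly above compound 1.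

Compound 4 `CC(Oc1ccc(Oc2ccc(C(F)(F)F)cc2)cc1)C(=O)Cn1nnc(-c2ccc(Cl)cc2)n1` differs from compound 3 in one place: trifluoromethyl in place of fluoro on an aromatic carbon. The same exchange, trifluoromethyl in place of fluoro on an aromatic carbon, has already been seen once, in the step of a number 0.90 log units higher from compound 1 to compound 2 (beyond the scatter), which was modest but beyond the scatter. That step is the only one that bears directly on the change at hand, and a step of comparable size and direction in this assay is therefore expected here, that is a number 0.90 log units higher from compound 3 to compound 4 (beyond the scatter). On this basis compound 4 is estimated at 7.1, with a range from 6.6 to 7.6.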

Compound 4, partition coefficient: 7
Estimate against measurement, compound 4: 0.10 log units above; the measured number falls inside the stated range.
By their numbers in this assay, from the lowest: compound 1; then compounds 2 and 3 (each within the scatter of the next); then compound 4.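

In this assay the exchange of fluoro for trifluoromethyl now appears with chloro elsewhere in the molecule, and a number 0.80 log units higher from compound 3 to compound 4 (beyond the scatter) runs the same way as a number 0.90 log units higher from compound 1 to compound 2 (beyond the scatter) where that chloro is absent. Chloro in place of hydrogen likewise gives a number 0.80 log units higher from compound 2 to compound 4 (beyond the scatter) with trifluoromethyl in the molecule, the same direction as a number 0.90 log units higher from compound 1 to compound 3 (beyond the scatter) with fluoro there. Each change thus raises the number whichever of these groups holds the other place, with none of the four compounds going against this, and nothing at hand gives a reason for it.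

The compounds shown leave open whether other groups at this place, such as an amine or a carboxylic acid, would follow the same course. They also leave open whether chloro and trifluoromethyl would keep these steps on a core with a longer chain.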